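Moving the methyl on the aryl group of compound 2

The source may report more compounds than this note shows. Statements on the series, on what has been measured and on what is new or still open speak of the compounds shown alone.

Measured so far:
Compound 1 `COc1cccc(-c2nc3cccc(-c4cc(OC)c(OC)c(OC)c4)c3o2)c1`: > 25000 nM
Compound 2 `COc1ccc(-c2nc3cccc(-c4cc(OC)c(OC)c(OC)c4)c3o2)cc1OC`: 1300 nM
Compound 3 `COc1cc(-c2cccc3nc(-c4ccc(C)cc4)oc23)cc(OC)c1OC`: 3200 nM

In a functional assay on U-251 cells (Homo sapiens) for antiproliferative activity, read by MTT assay, with a stated time of 48 h (on this read-out lower numbers stand for stronger inhibition and higher numbers for weaker inhibition), compound 2 gives 1300 nM, the lowest of the two numbers, with compound 3 the nearest at a 2.5-fold higher number from compound 2 to compound 3 (0.39 log units; beyond the scatter). For compound 1 only a limit is reported, > 25000 nM, so its number lies beyond the range of this assay (the limit of > 25000 nM in this assay, at which 1 of the 3 values shown sits).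

Compound 4 `COc1cc(-c2cccc3nc(-c4cccc(C)c4)oc23)cc(OC)c1OC` is still unmeasured. It differs from compound 2 in one place: 3-methylphenyl in place of 3,4-dimethoxyphenyl on an aromatic carbon.

Among the compounds with values here, three steps bear on this change. The step of a 2.5-fold higher number from compound 2 to compound 3 (0.39 log units; beyond the scatter) shows that swapping the 3,4-dimethoxyphenyl for a 4-methylphenyl costs only a modest amount. The step of an at least 19-fold lower number from compound 1 to compound 2 (1.28 log units; beyond the scatter) shows that adding a methoxy to give the 3,4-dimethoxyphenyl brings a large gain, and the step of an at least 7.8-fold lower number from compound 1 to compound 3 (0.89 log units; beyond the scatter) shows that the 4-methylphenyl is far better than the 3-methoxyphenyl. A 3-methylphenyl places its only substituent where the 3-methoxyphenyl of compound 1 carried its methoxy, so a weakening beyond the scatter is expected, larger than the loss to compound 3. Compound 4 is therefore expected to come in near 8000 nM (between 2500 nM and 25000 nM), a step of a 6.2-fold higher number from compound 2 to compound 4 (0.79 log units; beyond the scatter).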

Compound 4, half-maximal inhibitory concentration: > 25000 nM
Compound 4 ended at the assay's limit; the forecaster's own chance of this, stated with the estimate: 25%; middle value at least 3.1-fold (0.49 log units) from the limit.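

In this assay, exchanging the 4-methylphenyl for the 3-methylphenyl, the same group with its methyl moved, gives an at least 7.8-fold higher number from compound 3 to compound 4 (0.89 log units; beyond the scatter), so a shift of one small group on this ring can decide whether a number is reached at all. Replacing the 3,4-dimethoxyphenyl with the 3-methylphenyl gives an at least 19-fold higher number from compound 2 to compound 4 (1.28 log units; beyond the scatter), which shows that the modest cost seen earlier for leaving the 3,4-dimethoxyphenyl holds for the 4-methylphenyl and does not carry over to every methylphenyl. Compound 1 with its 3-methoxyphenyl and compound 4 with its 3-methylphenyl both stand at a limit of the assay rather than at a number, so the step between them cannot be read: the limit of > 25000 nM in this assay, at which 2 of the 4 values shown sit.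

The compounds shown do not tell whether a single methoxy in the 4 position, as in a 4-methoxyphenyl, would perform like the 3,4-dimethoxyphenyl of compound 2 or like the 4-methylphenyl of compound 3. Going by these compounds, it also remains open how other groups on this ring would fare, such as a 4-chlorophenyl, a 4-aminophenyl or a 4-carboxyphenyl.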